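Swapping benzofuran for methylindole on a long-chain threonine amide

The source may report more compounds than this note shows. Statements on the series, on what has been measured and on what is new or still open speak of the compounds shown alone.

Compound 3 (`CCCCCCCCCCCCCCCCCCNC(=O)[C@@H](NC(=O)c1cc2ccccc2o1)[C@@H](C)O`) is recorded in a functional assay on SW-620 cells (Homo sapiens) for cytotoxicity, read by MTT assay, with a stated time of 48 h (a lower number here means a stronger inhibitor, a higher number a weaker inhibitor), only as a limit, > 200000 nM, so its standing among the others is open. Compound 2 (`CCCCCCCCCCCCCCCCCCNC(=O)[C@@H](NC(=O)c1cccs1)[C@@H](C)O`) gives 200000 nM in this assay. The step from the two, a number no lower from compound 2 to compound 3 (the limit leaves the size open), is of unreadable size because of the limit of > 200000 nM in this assay, at which 1 of the 3 values shown sits. Compound 1 (`CCCCCCCCCCCCCCNC(=O)[C@@H](NC(=O)c1cc2ccccc2n1C)[C@@H](C)O`), which carries the shorter tetradecyl chain, gives 21500 nM in this assay.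

Compound 4 (`CCCCCCCCCCCCCCCCCCNC(=O)[C@@H](NC(=O)c1cc2ccccc2n1C)[C@@H](C)O`) differs from compound 3 by 1-methyl-1H-indol-2-yl in place of 1-benzofuran-2-yl on a carbonyl carbon. Within the data shown here, no measured step covers exactly this exchange on the octadecyl chain; the nearest information is that compound 1, with the same acyl group on a shorter chain, sits well inside the measurable range while compound 3 does not. Compound 4 is therefore expected to move toward stronger inhibition, a step of about an at least 2.5-fold lower number from compound 3 to compound 4 (0.39 log units; beyond the scatter), though with wide uncertainty. For compound 4 a value of 80000 nM is estimated in this assay, within 25000 nM to 200000 nM.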

Compound 4, half-maximal inhibitory concentration: 124000 nM
For compound 4 the middle estimate is 1.6-fold (0.19 log units) below the measured one, within the range that was stated.
By their numbers in this assay, from the lowest: compound 1; then compounds 4 and 2 (each within the scatter of the next).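

Going by these compounds, on the octadecyl chain, the exchange at this carbonyl carbon gives only an at least 1.6-fold lower number from compound 3 to compound 4 (0.20 log units; that floor lies within the scatter), and its true size stays open: the limit of > 200000 nM in this assay, at which 1 of the 4 values shown sits. Set against the thiophen-2-yl amide, the same place shows a 1.6-fold lower number from compound 2 to compound 4 (0.21 log units; within the scatter), so on this chain the 1-methyl-1H-indol-2-yl and thiophen-2-yl groups are not told apart in this assay. With the acyl group held fixed, the chain gives a step beyond the scatter, from tetradecyl to octadecyl: a 5.8-fold higher number from compound 1 to compound 4 (0.76 log units; beyond the scatter).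

The compounds shown leave open whether 1-benzofuran-2-yl or thiophen-2-yl on the tetradecyl chain would give values like that of the 1-methyl-1H-indol-2-yl group there. They also leave open how a dodecyl chain, or an indol-2-yl group without the methyl, would read in this assay.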